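A few compounds are considered here, and "the series" means these few. Any claim that something is new, unique, unknown or untested is made for them only; others in the source may bear on it.

Three ureas on a shared core have been run in a functional assay on MCF7 cells (Homo sapiens), read by MTT assay, with a stated time of 72 h; a higher number here means a weaker inhibitor, a lower number a stronger inhibitor. Compound 1 `COc1cc(NC(C)CCCNC(=O)NCc2ccncc2)c2ncccc2c1` gives 30000 nM. Compound 2 `COc1cc(NC(C)CCCNC(=O)NCc2ccccc2)c2ncccc2c1` gives 25000 nM, so a 1.2-fold lower number from compound 1 to compound 2 (0.08 log units; within the scatter). Compound 3 `COc1cc(NC(C)CCCNC(=O)NC2CCCC2)c2ncccc2c1` gives 30000 nM; no change at the digits printed from compound 1 to compound 3 (within the scatter) and a 1.2-fold higher number from compound 2 to compound 3 (0.08 log units; within the scatter). Compound 3 therefore sits level with compound 1, and all three numbers lie within the scatter of one another.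

Compound 4 `COc1cc(NC(C)CCCNC(=O)n2nnc3ccccc32)c2ncccc2c1` takes the next step: a group of 9 heavy atoms (6 carbon, 3 nitrogen; one five-membered aromatic ring with 3 hetero atoms, one six-membered aromatic ring of carbon only) in place of a group of 6 heavy atoms (5 carbon, 1 nitrogen; one five-membered non-aromatic ring of carbon only), on a carbonyl carbon. Within the data shown here, every measured step so far has varied this same urea terminus and none has moved the number beyond the scatter, so no step points to a direction here. The expectation is for no change beyond the scatter, no change at the digits printed from compound 3 to compound 4 (within the scatter). Compound 4 is estimated at 30000 nM, in the range 10000 nM to 90000 nM.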

Compound 4, half-maximal inhibitory concentration: > 100000 nM
Compound 4 gave a limit, no number (the forecaster's own chance of this, stated with the estimate: 20%); middle value at least 3.3-fold (0.52 log units) away from the limit.
By their numbers in this assay, from the lowest: compounds 2, 1 and 3 (each within the scatter of the next). At a limit, above all of these: compound 4.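

In this assay compound 4 gives a limit, not a number: the limit of > 100000 nM in this assay, at which 1 of the 4 values shown sits. The urea terminus, silent across compounds 1, 2 and 3, now moves the result beyond the scatter, with an at least 3.3-fold higher number from compound 3 to compound 4 (0.52 log units; beyond the scatter) and an at least 4.0-fold higher number from compound 2 to compound 4 (0.60 log units; beyond the scatter) and an at least 3.3-fold higher number from compound 1 to compound 4 (0.52 log units; beyond the scatter). Among these compounds, compound 4 is also the only compound here whose group on the carbonyl carbon has 0 hydrogen-bond donors and no urea hydrogen.

From the compounds shown here alone, whether the loss follows that missing hydrogen or the fused aromatic rings stays open. A morpholine bound through its nitrogen, or an N-methylcyclopentylamino group, on the carbonyl carbon would help separate the two.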